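Swapping iodo for aminoamino on an aromatic carbon

A few compounds are considered here, and "the series" means these few. Any claim that something is new, unique, unknown or untested is made for them only; others in the source may bear on it.

Measured in an ADME assay on L6 cells (Rattus norvegicus) for cytotoxicity; on this read-out lower numbers stand for stronger inhibition and higher numbers for weaker inhibition:
- Compound 1 `C[C@H]1O[C@@H](n2cnc3c(N)nc(F)nc32)[C@H](O)[C@@H]1O`: 2100 nM
- Compound 2 `C[C@H]1O[C@@H](n2cnc3c(N)nc(I)nc32)[C@H](O)[C@@H]1O`: 110000 nM
- Compound 3 `CS[C@H]1O[C@@H](n2cnc3c(N)nc(I)nc32)[C@H](O)[C@@H]1O`: 137000 nM

Compound 2 stands at the high end of this small set, and its nearest neighbour differs only by a 1.2-fold higher number from compound 2 to compound 3 (0.10 log units; within the scatter). That step, methylsulfanyl in place of methyl on a saturated ring carbon, does not touch the site changed next. Compound 4 `C[C@H]1O[C@@H](n2cnc3c(N)nc(NN)nc32)[C@H](O)[C@@H]1O` keeps the core of compound 2 but carries aminoamino in place of iodo on an aromatic carbon.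

For the measured compounds named here, one measured step bears on this same carbon: a 52-fold higher number from compound 1 to compound 2 (1.72 log units; beyond the scatter), with iodo in place of fluoro. It shows that a swap there can move the number a long way. Going by the values given here, no measured compound carries aminoamino, so the size of the step remains uncertain. A moderate fall in this assay seems the likeliest outcome, and the estimate means a 4.4-fold lower number from compound 2 to compound 4 (0.64 log units; beyond the scatter). For compound 4 the expected value is 25000 nM, with an estimated range of 4000 nM to 150000 nM.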

Compound 4, half-maximal inhibitory concentration: 188000 nM
Beside the measured number, compound 4's estimate is 7.5-fold (0.88 log units) below it; measured number above the stated range.
By their numbers in this assay, from the lowest: compound 1; then compounds 2, 3 and 4 (each within the scatter of the next).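

In this assay, the swap of iodo for aminoamino on this aromatic carbon gives a 1.7-fold higher number from compound 2 to compound 4 (0.23 log units; within the scatter), so the two groups cannot be told apart here. Aminoamino brings hydrogen-bond donors and acceptors that iodo lacks, yet the numbers for these compounds stay within the scatter of each other. Fluoro is the group that stands apart at this carbon, since replacing it with aminoamino gives a 90-fold higher number from compound 1 to compound 4 (1.95 log units; beyond the scatter), so a second, quite different group now falls far from it in the same direction.

Nothing shown explains why fluoro differs from these two groups. Going by these compounds, it remains open whether chloro, hydroxy or methoxy on this carbon would fall with fluoro or with iodo and aminoamino, and whether fluoro would keep its distance with methylsulfanyl on the saturated ring carbon.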